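A Methyl-Bearing Nitroanilide Extends a Measured Nitro Step

The compounds below may be only part of what the source reports. "The series", "measured", "known", "first", "only" and "open" are said of these compounds alone.

compound 1 `CCn1cc(C(=O)Nc2ccccc2)c(=O)c2cc(F)c(N3CCNC(C)C3)c(F)c21` — 39300 nM
compound 2 `CCn1cc(C(=O)Nc2cccc([N+](=O)[O-])c2)c(=O)c2cc(F)c(N3CCNC(C)C3)c(F)c21` — 3240 nM

In a functional assay on A549 cells (Homo sapiens) for cytotoxicity, read by MTT assay (a lower number here means a stronger inhibitor, a higher number a weaker inhibitor), compound 1 holds the highest of the two numbers shown; its nearest neighbour, compound 2, lies well below it by the step of a 12-fold lower number from compound 1 to compound 2 (1.08 log units; beyond the scatter). Compound 3 `CCn1cc(C(=O)Nc2ccc(C)c([N+](=O)[O-])c2)c(=O)c2cc(F)c(N3CCNC(C)C3)c(F)c21` is reached from compound 1 by 4-methyl-3-nitrophenyl in place of phenyl on an amide-type nitrogen. Among the compounds with values here, the only measured step bearing on this change is a 12-fold lower number from compound 1 to compound 2 (1.08 log units; beyond the scatter), which brings in the same nitro that the 4-methyl-3-nitrophenyl carries. For compound 3 a step of similar size and the same downward direction in this assay is expected, an 11-fold lower number from compound 1 to compound 3 (1.05 log units; beyond the scatter). Compound 3 is estimated at 3500 nM, within 1000 nM to 12000 nM.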

Compound 3, half-maximal inhibitory concentration: 3700 nM
For compound 3 the middle estimate is 1.1-fold (0.02 log units) below the measured one; the range from low to high includes it.
By their numbers in this assay, from the lowest: compounds 2 and 3 (each within the scatter of the next); then compound 1.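

In this assay, the added methyl gives a 1.1-fold higher number from compound 2 to compound 3 (0.06 log units; within the scatter), so on this ring the methyl adds no step beyond the scatter when the nitro is present. With 4-methyl-3-nitrophenyl in place of phenyl on the amide-type nitrogen, the change gives an 11-fold lower number from compound 1 to compound 3 (1.03 log units; beyond the scatter), so the large step seen with the nitro alone persists alongside the methyl. Nothing measured here explains either step. Open, as far as these compounds go, is what the methyl does on the anilide without the nitro. Also open, from the compounds shown here alone, is whether an amine or a carboxylic acid in place of the nitro would keep the large step.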